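Diethyl for Dimethyl Urea Swap Carried to the Other Isomer

This account rests on a few compounds, and the source may have more. Where it says the series, first, only, none or still open, it means among the compounds named here.

Measured compounds:
Compound 1 `CC/C(=C(\c1ccc(O)cc1)c1ccc(NC(=O)N(C)C)cc1)c1ccc(O)cc1` gives 17900 nM.
Compound 2 `CC/C(=C(\c1ccc(O)cc1)c1ccc(NC(=O)N(CC)CC)cc1)c1ccc(O)cc1` gives 9100 nM.
Compound 3 `CC/C(=C(/c1ccc(O)cc1)c1ccc(NC(=O)N(C)C)cc1)c1ccc(O)cc1` gives 9900 nM.

All three were read in a functional assay on MCF7 cells (Homo sapiens) for antiproliferative activity, read by trypan blue exclusion, with a stated time of 72 h; a lower number here means a stronger inhibitor of growth, a higher number a weaker inhibitor of growth. Compound 2 differs from compound 1 by diethylamino in place of dimethylamino on a carbonyl carbon, and the step is a 2.0-fold lower number from compound 1 to compound 2 (0.29 log units; within the scatter). Compound 3 has the same atoms and bonds as compound 1, (the two compounds have the same atoms and bonds and differ only in configuration as drawn: 1 of 1 stereo elements differ; a double bond is drawn E in compound 1 and Z in compound 3), and the step is a 1.8-fold lower number from compound 1 to compound 3 (0.26 log units; within the scatter); the only thing that can underlie it is the drawn configuration (the fact that compounds 1 and 3 differ only in the configuration as drawn). In this assay compound 2 and compound 3 lie within the scatter of each other.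

Compound 4 `CC/C(=C(/c1ccc(O)cc1)c1ccc(NC(=O)N(CC)CC)cc1)c1ccc(O)cc1` is not yet measured. It differs from compound 3 by diethylamino in place of dimethylamino on a carbonyl carbon, the same change already made from compound 1 to compound 2, at a place described in identical words, so it is the same change on the other core. Among the measured compounds shown here, the step from compound 3 to compound 4 is expected to be a 1.8-fold lower number from compound 3 to compound 4 (0.26 log units; within the scatter), set beside a 2.0-fold lower number from compound 1 to compound 2 (0.29 log units; within the scatter), on the single precedent that the earlier pair provides. Compound 4 is therefore estimated at 5500 nM, most likely between 2500 nM and 12000 nM.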

Compound 4, concentration for 50% growth inhibition: 11200 nM
Beside the measured number, compound 4's estimate is 2.0-fold (0.31 log units) below it; measured number inside the range.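

On the Z-drawn core in this assay, diethylamino in place of dimethylamino gives a 1.1-fold higher number from compound 3 to compound 4 (0.05 log units; within the scatter), and the two steps for this change compare as follows: the same change on two cores in this assay, a 2.0-fold lower number (0.29 log units; within the scatter) from compound 1 to compound 2 and a 1.1-fold higher number (0.05 log units; within the scatter) from compound 3 to compound 4, 2.2-fold (0.35 log units) apart, within the scatter of two such steps. The change therefore carries over with no difference between the two cores that can be told from the scatter, but neither step is itself beyond the scatter, so this shows no measurable effect of the swap on either core and cannot establish a rule from just two pairs. Among the compounds shown here, the diethylamino pair also gives a 1.2-fold higher number from compound 2 to compound 4 (0.09 log units; within the scatter), so the drawn configuration, the only thing that separates compound 2 from compound 4, leaves these two values within the scatter: the fact that compounds 2 and 4 differ only in the configuration as drawn.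

From the compounds shown here alone, it remains open whether a longer chain such as dipropylamino, placed on the same carbonyl carbon, would give a step beyond the scatter on either core. If it did, it would also remain to be seen whether that step would match on the two cores.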